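The source may report more compounds than this note shows. Statements on the series, on what has been measured and on what is new or still open speak of the compounds shown alone.

Working notes on the series. The shared core of compound 2 `CN(C(=O)NC(=O)c1ccc(Cl)cc1Cl)c1nc(C(F)(F)F)c(C(=O)N/N=C/c2ccc(C(F)(F)F)cc2)s1` carries two aryl groups that have been varied. In a functional assay on MCF7 cells (Homo sapiens) for inhibition, read by MTT assay, with a stated time of 72 h (a lower number here means a stronger inhibitor, a higher number a weaker inhibitor), compound 2 gives 8.42 ug/mL. Compound 1 `CN(C(=O)NC(=O)c1ccc(Cl)cc1Cl)c1nc(C(F)(F)F)c(C(=O)N/N=C/c2cccc(C(F)(F)F)c2)s1` differs only at the carbon with a double bond to nitrogen and in this assay compound 1 gives 10.7 ug/mL; the step of a 1.3-fold lower number from compound 1 to compound 2 (0.10 log units; within the scatter) leaves the two within the scatter of each other.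

Compound 3 `CN(C(=O)NC(=O)c1ccc(C(F)(F)F)cc1)c1nc(C(F)(F)F)c(C(=O)N/N=C/c2ccc(C(F)(F)F)cc2)s1` is not yet measured. It changes the other end of the molecule: 4-(trifluoromethyl)phenyl in place of 2,4-dichlorophenyl on a carbonyl carbon. For the measured compounds named here, no measured step touches this carbonyl carbon, so nothing measured bears directly on the change; the one measured step, at the other aryl group, stayed within the scatter. On this basis no step beyond the scatter is expected, with the range kept wide for want of a precedent. For compound 3 the expected value in this assay is 8.5 ug/mL, between 3 ug/mL and 25 ug/mL, which is an expected step of a 1.0-fold higher number from compound 2 to compound 3 (0.00 log units; within the scatter).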

Compound 3, half-maximal inhibitory concentration: > 100 ug/mL
Compound 3: only a limit was reported; the forecaster's own chance of this, stated with the estimate: 5%; middle value at least 11-fold (1.07 log units) away from the limit.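

For the compounds shown here, the aryl group on the carbonyl carbon is the first place where a single change gives a step beyond the scatter: in this assay, 4-(trifluoromethyl)phenyl in place of 2,4-dichlorophenyl gives an at least 11-fold higher number from compound 2 to compound 3 (1.07 log units; beyond the scatter). For compound 3 the reading is a limit and not a number: the limit of > 100 ug/mL in this assay, at which 1 of the 3 values shown sits. The one earlier step, a 1.3-fold lower number from compound 1 to compound 2 (0.10 log units; within the scatter), stayed within the scatter, so among the compounds shown the carbonyl end of the molecule is the only place where a change has moved the number beyond it.

Going by these compounds alone, still open is whether the step follows from the two chlorine atoms leaving or from the trifluoromethyl group entering, since the single change does both at once. A 4-chlorophenyl or an unsubstituted phenyl on this carbonyl carbon would separate the two in this assay.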